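Swapping Chloro for Methoxy on a Weak Inhibitor

The compounds below may be only part of what the source reports. "The series", "measured", "known", "first", "only" and "open" are said of these compounds alone.

Within the data shown here, compound 3 `C/C(=N\NC(=O)c1cc(-c2ccc(Cl)cc2)nn1Cc1ccc(C(C)(C)C)cc1)c1cc(Cl)cc(Cl)c1O` gives 7900 nM in a functional assay on A549 cells (Homo sapiens) for inhibition, read by MTT assay, with a stated time of 48 h (a higher number here means a weaker inhibitor, a lower number a stronger inhibitor), the highest of the three numbers measured so far. Among the measured compounds shown here, compound 1 `C/C(=N\NC(=O)c1cc(-c2ccccc2)nn1Cc1ccc(C(C)(C)C)cc1)c1cc(C)ccc1O` gives 6100 nM in this assay, which lies within the scatter of compound 3, while compound 2 `C/C(=N\NC(=O)c1cc(-c2ccc(Cl)cc2)nn1Cc1ccc(C(C)(C)C)cc1)c1cc(Cl)ccc1O` gives 280 nM; the step of a 28-fold higher number from compound 2 to compound 3 (1.45 log units; beyond the scatter) is the one large change recorded. Compound 4 `COc1ccc(-c2cc(C(=O)N/N=C(\C)c3cc(Cl)cc(Cl)c3O)n(Cc3ccc(C(C)(C)C)cc3)n2)cc1` differs from compound 3 by methoxy in place of chloro on an aromatic carbon. For the measured compounds named here, no measured pair isolates this change: compound 1 and compound 2 differ in more than one place, so their values give no clean guide. Going by the values given here, with no step bearing on the change, the expected step is a 1.1-fold lower number from compound 3 to compound 4 (0.05 log units; within the scatter), within the scatter. Compound 4 is therefore estimated at 7000 nM, with a range from 2000 nM to 25000 nM.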

Compound 4, half-maximal inhibitory concentration: 2080 nM
The estimate for compound 4 lay 3.4-fold (0.53 log units) above the measured number; measured number inside the range.
By their numbers in this assay, from the lowest: compound 2; then compound 4; then compounds 1 and 3 (each within the scatter of the next).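

In this assay, replacing 4-chlorophenyl with 4-methoxyphenyl gives a 3.8-fold lower number from compound 3 to compound 4 (0.58 log units; beyond the scatter), a modest step but one beyond the scatter. Among these compounds, this is the first measured pair to isolate a change at this position, and it shows that, with the rest of compound 3 held fixed, the group placed here affects the measured number. Nothing measured here explains the shift. From the compounds shown here alone, it remains open whether an amine or an ethoxy group at the same place would lower the number further, and whether methoxy would give a similar step in compound 2.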